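Aldehyde to carboxylic acid on the chain of compound 2

The compounds below may be only part of what the source reports. "The series", "measured", "known", "first", "only" and "open" are said of these compounds alone.

Compound 1 `Cn1nc(Cc2nnc(SCC(=O)Nc3ccc(Cl)cc3Cl)n2CCC=O)c2ccccc2c1=O` and compound 2 `Cn1nc(Cc2nnc(SCCCCCCCC(=O)Nc3ccc(Cl)cc3Cl)n2CCC=O)c2ccccc2c1=O` share one core and differ in the length of the thioether chain. Within the data shown here, in an assay on 32D cells for inhibition of interleukin-15 (Mus musculus), read by resazurin assay, with stated times of 30 min and 2.5 days, in the presence of a further agent that is not named here (a lower number here means a stronger inhibitor, a higher number a weaker inhibitor), compound 1 gives 6400 nM, and compound 2 gives 5500 nM; the two numbers lie within the scatter of each other, so compound 2 stands level with compound 1 on the numbers so far. Compound 3 `Cn1nc(Cc2nnc(SCCCCCCCC(=O)Nc3ccc(Cl)cc3Cl)n2CCC(=O)O)c2ccccc2c1=O` keeps the long chain of compound 2 and changes only the chain end: hydroxy in place of hydrogen on a carbonyl carbon. Among the measured compounds shown here, no measured pair isolates this change; the expected step is no change at the digits printed from compound 2 to compound 3 (within the scatter), none beyond the scatter. For compound 3 the estimate in this assay is 5500 nM, expected between 2000 nM and 15000 nM.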

Compound 3, half-maximal inhibitory concentration: > 30000 nM
Compound 3 gave a limit, no number; the forecaster's own chance of this, stated with the estimate: 10%; at least 5.4-fold (0.73 log units) between middle value and limit.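

The chain end, the same in compound 1 and compound 2, proves sensitive: in this assay, formyl to carboxy gives an at least 5.4-fold higher number from compound 2 to compound 3 (0.73 log units; beyond the scatter). Compound 3 reads as a limit, not a number: the limit of > 30000 nM in this assay, at which 1 of the 3 values shown sits. The thioether chain lengths of compound 1 and compound 2 stand within the scatter of each other, whereas this single added oxygen moves the result beyond it.

As far as these compounds go, whether a methyl ester, a primary amide or an amine at this chain end would behave like the formyl or the carboxy group stays open. So does the effect of the same change on the shorter thioether chain of compound 1.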